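Removing the Methoxy from Compound 1

This account rests on a few compounds, and the source may have more. Where it says the series, first, only, none or still open, it means among the compounds named here.

Within the data shown here, compound 1 `COc1ccc2c(C(=O)/C(C#N)=C/c3c[nH]c4cc(F)ccc34)c[nH]c2c1` gives 800 nM in a functional assay on A549 cells (Homo sapiens) for cytotoxicity, read by WST assay, with a stated time of 48 h (a lower number here means a stronger inhibitor, a higher number a weaker inhibitor), the lowest of the three numbers measured so far. Compound 3 `COc1ccc2c(C(=O)/C(C#N)=C/c3c[nH]c4ccccc34)c[nH]c2c1` gives 7500 nM, and compound 2 `COc1ccc2[nH]cc(/C=C(\C#N)C(=O)c3c[nH]c4cc(F)ccc34)c2c1` gives 26300 nM. Among the measured compounds shown here, the only measured single change is a 9.4-fold higher number from compound 1 to compound 3 (0.97 log units; beyond the scatter), a loss when one small aromatic substituent is removed. Compound 4 `N#C/C(=C\c1c[nH]c2cc(F)ccc12)C(=O)c1c[nH]c2ccccc12` differs from compound 1 by hydrogen in place of methoxy on an aromatic carbon. For the measured compounds named here, no measured pair removes this methoxy, so the size of its effect is not known directly; the one comparable removal, from compound 1 to compound 3, weakened activity. Compound 4 is therefore expected to be somewhat weaker than compound 1, estimated at 2500 nM with a range of 600 nM to 10000 nM. That estimate means an expected step of a 3.1-fold higher number from compound 1 to compound 4 (0.49 log units; beyond the scatter).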

Compound 4, half-maximal inhibitory concentration: 22700 nM
The estimate for compound 4 lay 9.1-fold (0.96 log units) below the measured number, and the stated range ends below it.
By their numbers in this assay, from the lowest: compound 1; then compound 3; then compounds 4 and 2 (each within the scatter of the next).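

The methoxy on this aromatic carbon matters for activity in this assay: its replacement by hydrogen gives a 28-fold higher number from compound 1 to compound 4 (1.45 log units; beyond the scatter), a large step, where the fluoro removal was a modest one. Compound 4 keeps the fluoro and compound 3 keeps the methoxy, yet both lose activity, so the fluoro alone does not preserve the number of compound 1 here. Nothing shown here gives a reason for the loss. Still open, going by these compounds, is whether an ethoxy or a hydroxyl on this carbon would retain the activity of compound 1. Also open, on these data alone, is what a chlorine there would do.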